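The source may hold more compounds than are shown below. What is called first, only, known or untested is meant among the compounds shown, and "the series" means these compounds.

Within the shared core, compound 3 `COc1cc(OC)cc(N2CCN(C(=O)c3oc(C)nc3-c3ccccc3)CC2)c1` gives 0.319 ug/mL in a toxicity assay on HUVEC cells (Homo sapiens) for inhibition (a lower number here means a stronger inhibitor of growth, a higher number a weaker inhibitor of growth), and stands at the lowest of the three numbers so far. Compound 2 `Cc1cc(C)cc(N2CCN(C(=O)c3oc(C)nc3-c3ccccc3)CC2)c1` gives 0.356 ug/mL in this assay, and the pair sits within the scatter, as a 1.1-fold lower number from compound 2 to compound 3 (0.05 log units; within the scatter) shows. Among the measured compounds shown here, compound 1 `Cc1nc(-c2ccccc2)c(C(=O)N2CCN(c3cccc(C#N)c3)CC2)o1` gives 2.52 ug/mL in this assay, and a 7.9-fold lower number from compound 1 to compound 3 (0.90 log units; beyond the scatter) and a 7.1-fold lower number from compound 1 to compound 2 (0.85 log units; beyond the scatter) are the only steps beyond the scatter. Compound 4 `Cc1nc(-c2ccccc2)c(C(=O)N2CCN(c3cccc(Cl)c3)CC2)o1` is not yet measured in this assay. The change is 3-chlorophenyl in place of 3,5-dimethoxyphenyl on an amine nitrogen in a ring. For the measured compounds named here, no measured step covers 3-chlorophenyl, but both 3-chlorophenyl in compound 4 and 3-cyanophenyl in compound 1 depart from the 3,5-dimethoxyphenyl of compound 3, so a 7.9-fold lower number from compound 1 to compound 3 (0.90 log units; beyond the scatter) bears on it most closely, and a part of that distance is expected to return. A number higher than that of compound 3 is therefore expected. Compound 4 is estimated at 0.9 ug/mL, with a range from 0.3 ug/mL to 3 ug/mL. The expected step of a 2.8-fold higher number from compound 3 to compound 4 (0.45 log units; beyond the scatter) would lie beyond the scatter but short of the full way back to compound 1.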

Compound 4, concentration for 50% growth inhibition: 0.463 ug/mL
Compound 4: middle estimate off by 1.9-fold (0.29 log units), on the high side; measured number inside the range.
By their numbers in this assay, from the lowest: compounds 3, 2 and 4 (each within the scatter of the next); then compound 1.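

At the aryl group on the amine nitrogen of the ring, 3-chlorophenyl sits level with both disubstituted groups in this assay: a 1.5-fold higher number from compound 3 to compound 4 (0.16 log units; within the scatter) and a 1.3-fold higher number from compound 2 to compound 4 (0.11 log units; within the scatter). Among these compounds, a second ring substituent is therefore not required for a number in this range, and the earlier steps, which changed the kind and count of substituents together, could not show this. With only chloro in place of cyano on an aromatic carbon, a 5.4-fold lower number from compound 1 to compound 4 (0.74 log units; beyond the scatter), which isolates the nitrile-bearing compound 1 as the one apart from the other three, though no measurement at hand explains the gap. From the compounds shown here alone, whether unsubstituted phenyl or 3-methoxyphenyl stays in the same range remains open. So does whether an amine or a carboxylic acid on that phenyl ring would track with chloro or with cyano.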